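The source may report more compounds than this note shows. Statements on the series, on what has been measured and on what is new or still open speak of the compounds shown alone.

Compound 2 `O=C(Nc1ccc(Oc2ccnc3[nH]ccc23)c(F)c1)c1cc2cccnc2n(-c2ccc(F)c(Cl)c2)c1=O` stands second highest of the three numbers in a functional assay on A549 cells (Homo sapiens) for antiproliferative activity, read by MTT assay, with a stated time of 72 h (a lower number here means a stronger inhibitor, a higher number a weaker inhibitor), at 630 nM; compound 1 `O=C(Nc1ccc(Oc2ccnc3[nH]ccc23)c(F)c1)c1cc2cccnc2n(-c2ccc(Br)cc2)c1=O` gives 210 nM and compound 3 `O=C(Nc1ccc(Oc2ccnc3[nH]ccc23)c(F)c1)c1cc2cccnc2n(-c2ccc(C(F)(F)F)cc2Cl)c1=O` gives 1020 nM. The measured steps are a 3.0-fold higher number from compound 1 to compound 2 (0.48 log units; beyond the scatter), a 4.9-fold higher number from compound 1 to compound 3 (0.69 log units; beyond the scatter) and a 1.6-fold higher number from compound 2 to compound 3 (0.21 log units; within the scatter), all at the aryl group on the other aromatic nitrogen. Going by the values given here, compound 4 `Cn1ccc2c(Oc3ccc(NC(=O)c4cc5cccnc5n(-c5ccc(F)c(Cl)c5)c4=O)cc3F)ccnc21` differs from compound 2 by methyl in place of hydrogen on an aromatic nitrogen; no measured step touches that position, so nothing sizes this change. The expectation for compound 4 is therefore a step of a 1.3-fold higher number from compound 2 to compound 4 (0.10 log units; within the scatter), no larger than the scatter in either direction. Compound 4 is estimated at 800 nM in this assay, within a range of 300 nM to 2500 nM.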

Compound 4, half-maximal inhibitory concentration: 3560 nM
Beside the measured number, compound 4's estimate is 4.5-fold (0.65 log units) below it, outside the stated range (above it).
By their numbers in this assay, from the lowest: compound 1; then compounds 2 and 3 (each within the scatter of the next); then compound 4.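

In this assay, going by these compounds alone, methyl in place of hydrogen on the aromatic nitrogen of the five-membered ring gives a 5.7-fold higher number from compound 2 to compound 4 (0.75 log units; beyond the scatter), so this position, which no earlier step touched, responds to even a single added carbon. This is one step, read only with the 3-chloro-4-fluorophenyl group of compound 2. No evidence at hand explains the change. As far as these compounds go, whether an ethyl group, a longer chain or a chain ending in an amine on this nitrogen would follow methyl remains open. Also open, from the compounds shown here alone, is whether methyl would give a similar step alongside the 4-bromophenyl group of compound 1.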